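This account rests on a few compounds, and the source may have more. Where it says the series, first, only, none or still open, it means among the compounds named here.

- compound 1 `O=C1c2c[n+]([O-])c3ccccc3c2C(=O)c2c1c1ccccc1n2Cc1cn([C@H]2O[C@H](CO)[C@@H](O)[C@H]2O)nn1`: 2680 nM
- compound 2 `O=C1c2c[n+]([O-])c3ccccc3c2C(=O)c2c1c1ccccc1n2Cc1cn(C[C@H](O)CO)nn1`: 1030 nM
- compound 3 `CCCN1CCN(CCCCn2c3c(c4ccccc42)C(=O)c2c[n+]([O-])c4ccccc4c2C3=O)CC1`: 320 nM

In a functional assay on A549 cells (Homo sapiens) for cytotoxicity, read by MTT assay, with a stated time of 72 h (a higher number here means a weaker inhibitor, a lower number a stronger inhibitor), compound 3 gives 320 nM as the lowest of the three numbers, so it is the strongest inhibitor measured so far. The next compound, compound 4 `O=C1c2c[n+]([O-])c3ccccc3c2C(=O)c2c1c1ccccc1n2CCCN1CCC(O)CC1`, has 4-hydroxypiperidin-1-yl in place of (4-propylpiperazin-1-yl)methyl on a saturated chain carbon, three bonds along the chain from an aromatic nitrogen. The counted change is 4-hydroxypiperidin-1-yl in place of (4-propylpiperazin-1-yl)methyl on a saturated chain carbon, three bonds along the chain from an aromatic nitrogen here.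

Among the compounds with values here, no measured step makes this exact swap. The nearest guide is a 3.2-fold lower number from compound 2 to compound 3 (0.51 log units; beyond the scatter), a modest step that replaced a dihydroxypropyl triazole side chain. The step of a 2.6-fold lower number from compound 1 to compound 2 (0.42 log units; beyond the scatter) is also modest and shows that side chains with hydroxy groups can differ too. Within the data shown here, compound 1 and compound 2 both carry such groups and both lie above compound 3, and no measured compound goes against this, though three compounds are few. Compound 4 regains a hydroxy group, so a modest rise in this assay is expected, and the expected size is a 1.7-fold higher number from compound 3 to compound 4 (0.24 log units; within the scatter) in this estimate. For compound 4 the estimated value is 550 nM, with an expected range of 190 nM to 1600 nM as its limits.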

Compound 4, half-maximal inhibitory concentration: 350 nM
Beside the measured number, compound 4's estimate is 1.6-fold (0.20 log units) above it; the range from low to high includes it.
By their numbers in this assay, from the lowest: compounds 3 and 4 (each within the scatter of the next); then compound 2; then compound 1.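

In this assay, the change to 4-hydroxypiperidin-1-yl on a saturated chain carbon, three bonds along the chain from an aromatic nitrogen, gives a 1.1-fold higher number from compound 3 to compound 4 (0.04 log units; within the scatter) and so leaves the two side chains indistinguishable, even though the entering group has fewer heavy atoms, one hydrogen-bond donor and no second ring nitrogen. Compound 4 also goes against the earlier pattern, in which the hydroxy-bearing side chains of compound 1 and compound 2 both gave higher numbers than compound 3, and the listed step of a 2.9-fold lower number from compound 2 to compound 4 (0.47 log units; beyond the scatter) shows that a hydroxy group at the end of a side chain can go with a clearly lower number. Nothing measured here explains these results. The compounds shown leave open how a plain piperidin-1-yl or a morpholin-4-yl group would read at this place. They also leave open whether a longer chain carrying 4-hydroxypiperidin-1-yl would keep the number of compound 4.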